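From 4-chlorophenyl to 4-fluorophenyl: compound 3 to compound 4

The source may hold more compounds than are shown below. What is called first, only, known or untested is meant among the compounds shown, and "the series" means these compounds.

- compound 1 `CN1CCC(C(c2ccccc2)N2CCN(C(=O)CC(c3ccccc3)c3ccccc3)CC2)CC1`: 63.6 ug/mL
- compound 2 `CN1CCC(CN2CCN(C(=O)CC(c3ccccc3)c3ccccc3)CC2)CC1`: 151 ug/mL
- compound 3 `CN1CCC(C(c2ccc(Cl)cc2)N2CCN(C(=O)CC(c3ccccc3)c3ccccc3)CC2)CC1`: 41 ug/mL

In a physicochemical assay for solubility, at pH 7.4 (a higher number here means a more soluble compound, a lower number a less soluble compound), compound 3 gives 41 ug/mL. Its two measured steps are a 1.6-fold lower number from compound 1 to compound 3 (0.19 log units; within the scatter) and a 3.7-fold lower number from compound 2 to compound 3 (0.57 log units; beyond the scatter). Compound 4 `CN1CCC(C(c2ccc(F)cc2)N2CCN(C(=O)CC(c3ccccc3)c3ccccc3)CC2)CC1` has fluoro in place of chloro on an aromatic carbon, para to a large group: fluoro in place of chloro on an aromatic carbon.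

For the measured compounds named here, no measured compound carries fluoro, so the evidence is indirect. Going by the values given here, the closest precedent is chloro in place of hydrogen at this same place, a 1.6-fold lower number from compound 1 to compound 3 (0.19 log units; within the scatter). The other two steps, a 2.4-fold higher number from compound 1 to compound 2 (0.38 log units; beyond the scatter) and a 3.7-fold lower number from compound 2 to compound 3 (0.57 log units; beyond the scatter), are larger, but each adds or removes a whole aromatic ring and says little about exchanging one halogen for another. A change beyond the scatter is therefore not expected, and any shift is expected to lean slightly upward, towards compound 1 at 63.6 ug/mL.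

The expected step is a 1.2-fold higher number from compound 3 to compound 4 (0.09 log units; within the scatter). For compound 4 the estimate is 50 ug/mL, with an expected range of 27 ug/mL to 90 ug/mL.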

Compound 4, solubility: 72.7 ug/mL
Beside the measured number, compound 4's estimate is 1.5-fold (0.16 log units) below it, within the range that was stated.
By their numbers in this assay, from the lowest: compounds 3, 1 and 4 (each within the scatter of the next); then compound 2.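

In this assay fluoro in place of chloro gives a 1.8-fold higher number from compound 3 to compound 4 (0.25 log units; within the scatter) and fluoro in place of hydrogen gives a 1.1-fold higher number from compound 1 to compound 4 (0.06 log units; within the scatter) at the same place, so hydrogen, chloro and fluoro on this aromatic carbon, para to a large group, are not told apart here. The larger change remains the one on the saturated chain carbon: 4-fluorophenyl in place of hydrogen gives a 2.1-fold lower number from compound 2 to compound 4 (0.32 log units; beyond the scatter) and 4-chlorophenyl in the same place gives a 3.7-fold lower number from compound 2 to compound 3 (0.57 log units; beyond the scatter) as steps beyond the scatter. The data shown offer no measurement that explains these numbers.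

As far as these compounds go, whether a methoxy group, a nitrile or a carboxylic acid on this aromatic carbon would move the number beyond the scatter stays open. So does the outcome of a small alkyl group such as methyl on the saturated chain carbon in place of the substituted phenyl ring.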